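Amide nitrogen substituent swap in a thienylmethyl amide series

A few compounds are considered here, and "the series" means these few. Any claim that something is new, unique, unknown or untested is made for them only; others in the source may bear on it.

Measured compounds:
compound 1 `Cc1ccc(OCC(=O)N(Cc2cccs2)c2ccn(C)n2)cc1`: 855 nM
compound 2 `CCN(Cc1cccs1)C(=O)c1cc2cc(C)ccc2[nH]1`: 2010 nM
compound 3 `CCN(Cc1cccs1)C(=O)COc1ccccc1`: 1400 nM

In an assay on HEK293 cells for agonist activity at transient receptor potential cation channel subfamily M member 8 (Homo sapiens), read by fluorescence and calcium flux, with a stated time of 15 min (a lower number here means that less compound is needed, a higher number that more compound is needed for the effect), compound 1 gives the lowest of the three numbers. Its nearest neighbour is compound 3, whose value lies within the scatter of compound 1; compound 2 sits beyond the scatter, higher than compound 1. Among the compounds with values here, no single-point step between the measured compounds is available.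

Compound 4 `CCC(C)N(Cc1cccs1)C(=O)COc1ccc(C)cc1` is the next entry. Against compound 1 the change is sec-butyl in place of 1-methyl-1H-pyrazol-3-yl on an amide-type nitrogen; the aryl ether part stays as it is. Compound 3 carries an ethyl on that same nitrogen with the phenoxyacetyl and gives 1400 nM, which is within the scatter of compound 1, so a saturated chain on the amide nitrogen has not moved the read-out much. The step from compound 1 to compound 4 is therefore expected to be small, a 1.2-fold higher number from compound 1 to compound 4 (0.07 log units; within the scatter), likely none beyond the scatter. Compound 4 is estimated at 1000 nM in this assay, with a range from 400 nM to 2500 nM.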

Compound 4, half-maximal effective concentration: 2000 nM
For compound 4 the middle estimate is 2.0-fold (0.30 log units) below the measured one, and the stated range covers the measured number.
By their numbers in this assay, from the lowest: compounds 1, 3, 4 and 2 (each within the scatter of the next, the first and the last beyond it).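

In this assay, within the data shown here, sec-butyl in place of 1-methyl-1H-pyrazol-3-yl on the amide-type nitrogen gives a 2.3-fold higher number from compound 1 to compound 4 (0.37 log units; beyond the scatter), the first step with only one place changed, and it lies beyond the scatter. Among these compounds, the read-out at this position therefore responds to the swap, although the step is modest and the exchange removes a five-membered aromatic ring and 2 hydrogen-bond acceptors together, so the single pair cannot separate these changes. No measured evidence bears on the origin of this step. As far as these compounds go, how a phenyl ring or a simple cyclohexyl on the same nitrogen would read in this assay remains open. Also open, from the compounds shown here alone, is whether a pyrazole without its methyl group would keep the number of compound 1.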